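From hydroxy to dimethylamino in the growth inhibition series

The source may hold more compounds than are shown below. What is called first, only, known or untested is meant among the compounds shown, and "the series" means these compounds.

In a functional assay on Gurav cells (Homo sapiens) for inhibition, read by sulforhodamine B assay (a lower number here means a stronger inhibitor of growth, a higher number a weaker inhibitor of growth), compound 3 (`Oc1ccc(-c2ccc(-c3ccc(-c4nc5ccccc5[nH]4)cc3)cc2)cc1`) gives 100000 nM and stands level with compound 2 (`FC(F)(F)Oc1ccc(-c2ccc(-c3ccc(-c4nc5ccccc5[nH]4)cc3)cc2)cc1`), which gives 100000 nM at the same digits. Together these are the highest of the three numbers so far. Compound 1 (`Cc1ccc2[nH]c(-c3ccc(-c4ccc(-c5ccc(N(C)C)cc5)cc4)cc3)nc2c1`) gives 6240 nM in this assay, lower than both and beyond the scatter.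

The next structure is compound 4 (`CN(C)c1ccc(-c2ccc(-c3ccc(-c4nc5ccccc5[nH]4)cc3)cc2)cc1`), with dimethylamino in place of hydroxy on an aromatic carbon, para to a large group (dimethylamino in place of hydroxy on an aromatic carbon).

Among the compounds with values here, one measured step bears directly on this place: no change at the digits printed from compound 2 to compound 3 (within the scatter), with hydrogen in place of trifluoromethyl on an oxygen on an aromatic ring. On that step alone, no movement would be expected. Within the data shown here, compound 1 points the other way, since it also carries dimethylamino and is the only compound with a clearly lower number. Its core is not identical to that of compound 4, so it is an imperfect guide. Among the measured compounds shown here, the expectation still leans on compound 1 at 6240 nM as the closest precedent, with a stronger inhibitor of growth anticipated. The expected change is an 11-fold lower number from compound 3 to compound 4 (1.05 log units; beyond the scatter) in this assay, a clear drop in the number. Compound 4 is estimated at 9000 nM, with an expected range from 3000 nM to 50000 nM as the likely span.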

Compound 4, concentration for 50% growth inhibition: 100000 nM
For compound 4 the middle estimate is 11-fold (1.05 log units) below the measured one; measured number outside the range, above it.
By their numbers in this assay, from the lowest: compound 1; then compounds 2, 3 and 4 (each within the scatter of the next).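

In this assay dimethylamino on this aromatic carbon, para to a large group, brings no gain over the other two groups tested there: the step reads no change at the digits printed from compound 3 to compound 4 (within the scatter) against hydroxy and no change at the digits printed from compound 2 to compound 4 (within the scatter) against trifluoromethoxy, so these three groups cannot be told apart at this place. The dimethylamino group therefore does not account for the lower number of compound 1, as the one remaining difference is a methyl on the core, with a 16-fold higher number from compound 1 to compound 4 (1.20 log units; beyond the scatter) on hydrogen in place of methyl on an aromatic carbon, a large step for so small a change. Nothing at hand gives a reason for this step.

Still open, as far as these compounds go, is whether that methyl lowers the number in the hydroxy and trifluoromethoxy compounds as well, or only together with dimethylamino, a question only the matched methyl analogues can settle. Also open, from the compounds shown here alone, is how an ethyl or a chlorine on that core carbon would read, and likewise a primary amine or a carboxylic acid in place of dimethylamino.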